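The compounds below may be only part of what the source reports. "The series", "measured", "known", "first", "only" and "open" are said of these compounds alone.

Measured so far in an ADME assay on MDCK cells (Canis lupus familiaris) for cytotoxicity, read by microscopy, with a stated time of 48 h; a higher number here means that more compound is tolerated, a lower number that less compound is tolerated:
Compound 1 `C[C@H]1[C@H](NCc2ccsc2)C[C@H]2C[C@@H]1C2(C)C` gives 50000 nM.
Compound 2 `C[C@H]1[C@H](NCc2ccoc2)C[C@H]2C[C@@H]1C2(C)C` gives > 100000 nM, which is a limit of the assay rather than a number.
Compound 3 `C[C@H]1[C@H](NCc2ccc(Br)s2)C[C@H]2C[C@@H]1C2(C)C` gives 43000 nM.

In this assay compound 3 holds the lowest of the two numbers; its nearest neighbour is compound 1, and a 1.2-fold lower number from compound 1 to compound 3 (0.07 log units; within the scatter). The next compound is compound 4 `C[C@H]1[C@H](NCc2nccs2)C[C@H]2C[C@@H]1C2(C)C`, with the change (1,3-thiazol-2-yl in place of 5-bromothiophen-2-yl on a saturated chain carbon bound to an amine nitrogen). Going by the values given here, two measured steps bear on this exchange of one five-membered aromatic ring for another: a 1.2-fold lower number from compound 1 to compound 3 (0.07 log units; within the scatter), while an at least 2.3-fold lower number from compound 2 to compound 3 (0.36 log units; beyond the scatter), a comparison that rests on (the limit of > 100000 nM in this assay, at which 1 of the 3 values shown sits). Such ring exchanges have moved the number only slightly, so compound 4 is expected to show a 1.3-fold higher number from compound 3 to compound 4 (0.11 log units; within the scatter), nothing beyond the scatter. Compound 4 is estimated at 55000 nM, between 25000 nM and 110000 nM.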

Compound 4, minimum cytotoxic concentration: > 100000 nM
Compound 4: no number, only a limit; the forecaster's own chance of this, stated with the estimate: 25%; at least 1.8-fold (0.25 log units) between middle value and limit.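

In this assay compound 4 gives > 100000 nM, which is a limit of the assay and not a number. A ring exchange at this place can therefore produce a real difference, as 1,3-thiazol-2-yl in place of 5-bromothiophen-2-yl gives an at least 2.3-fold higher number from compound 3 to compound 4 (0.36 log units; beyond the scatter), whereas 1,3-thiazol-2-yl in place of thiophen-3-yl gives an at least 2.0-fold higher number from compound 1 to compound 4 (0.30 log units; that floor lies within the scatter). The step from compound 2 to compound 4 cannot be read: the limit of > 100000 nM in this assay, at which 2 of the 4 values shown sit.

As far as these compounds go, whether the bromine or the ring's attachment matters more remains open. A plain thiophen-2-yl group at this place would help separate the two, and a pyridin-3-yl group would test a six-membered ring.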